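Trimming a Phenethyl Amide on a Lipoxygenase Inhibitor

The source may report more compounds than this note shows. Statements on the series, on what has been measured and on what is new or still open speak of the compounds shown alone.

Compound 1 `COc1ccc(/C=C2\SC(c3ccc(NC(=O)CCc4ccccc4)cc3)=NC2=O)cc1`: 260 nM
Compound 2 `O=C1N=C(c2ccc(Oc3ccccc3)cc2)S/C1=C\c1ccc(Oc2ccccc2)cc1`: 650 nM

Of the compounds shown here, two have been measured in an assay on cells for inhibition of Polyunsaturated fatty acid 5-lipoxygenase (Homo sapiens), read by HPLC, with stated times of 15 min and 10 min; on this read-out lower numbers stand for stronger inhibition and higher numbers for weaker inhibition. Compound 1 gives the lowest of the two numbers, so it is the stronger inhibitor here. Compound 2 gives 650 nM, and the gap from compound 1 to it lies beyond the usual scatter of such measurements.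

Compound 3 `CCC(=O)Nc1ccc(C2=NC(=O)/C(=C/c3ccc(OC)cc3)S2)cc1` is the next compound to be tested in this assay. It differs from compound 1 in one place: hydrogen in place of phenyl on a saturated chain carbon, two bonds along the chain from a carbonyl carbon. Everything else in the molecule stays as in compound 1. Going by the values given here, no pair of already measured compounds shows a change of this kind, so the size of the step cannot be read off from the data and must be estimated. Removing a whole aromatic ring from the amide chain is expected to cost some potency, but not much more than the scatter itself. The expected step is a 2.1-fold higher number from compound 1 to compound 3 (0.33 log units; beyond the scatter) in the direction of weaker inhibition. Compound 3 is therefore estimated at 550 nM, with a likely range from 180 nM to 1700 nM.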

Compound 3, half-maximal inhibitory concentration: 1840 nM
Beside the measured number, compound 3's estimate is 3.3-fold (0.52 log units) below it; measured number above the stated range.
By their numbers in this assay, from the lowest: compound 1; then compound 2; then compound 3.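

In this assay, the phenyl on the amide chain turns out to matter: cutting phenethylcarbonyl back to propanoyl, with everything else unchanged, gives a 7.1-fold higher number from compound 1 to compound 3 (0.85 log units; beyond the scatter), in the direction of weaker inhibition. Going by these compounds alone, this is the first comparison here between compounds that differ in one place, and it shows that potency depends on what sits on this saturated chain carbon, two bonds along the chain from the carbonyl carbon. Within the data shown here, nothing measured so far bears on why the loss occurs.

Still open, from the compounds shown here alone, is whether a cyclohexyl ring or a pyridine ring at this place would bring the number back toward that of compound 1, which would show how much of the phenyl is really needed. Going by these compounds, it is also open whether the step keeps its size when the methoxy group of compound 1 is replaced by a chlorine atom.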